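This account rests on a few compounds, and the source may have more. Where it says the series, first, only, none or still open, it means among the compounds named here.

Among the measured compounds shown here, in a physicochemical assay for lipophilicity, measured as octanol-water partition (on this read-out higher numbers stand for higher lipophilicity and lower numbers for lower lipophilicity), compound 1 `Cc1c(NCc2nnc(-c3ccccc3O)o2)c(=O)n(-c2ccccc2)n1C` gives 1.71 and compound 2 `Cc1cccc(-c2nnc(CNc3c(C)n(C)n(-c4ccccc4)c3=O)o2)c1` gives 2.39, the higher of the two numbers so far. Compound 3 `Cc1ccc(-c2nnc(CNc3c(C)n(C)n(-c4ccccc4)c3=O)o2)cc1` carries 4-methylphenyl in place of 3-methylphenyl on an aromatic carbon. The two have the same atoms, joined differently. For the measured compounds named here, the only measured step, a number 0.68 log units higher from compound 1 to compound 2 (beyond the scatter), exchanged a different pair of groups, so it bears on this change only loosely and sets no direction for it. The expected change is a number 0.01 log units higher from compound 2 to compound 3 (within the scatter), which would be no step beyond the scatter. The estimate for compound 3 is 2.4, with an expected range of 2.05 to 2.75.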

Compound 3, partition coefficient: 2.48
The estimate for compound 3 lay 0.08 log units below the measured number, within the range that was stated.
By their numbers in this assay, from the lowest: compound 1; then compounds 2 and 3 (each within the scatter of the next).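

In this assay the change from 3-methylphenyl to 4-methylphenyl gives a number 0.09 log units higher from compound 2 to compound 3 (within the scatter), so this position does not separate these two methylphenyl groups on this read-out. Placing 4-methylphenyl where 2-hydroxyphenyl stood gives a number 0.77 log units higher from compound 1 to compound 3 (beyond the scatter), so compound 1 stays apart from compound 3 as well as from compound 2. No supporting data offer an explanation for either step.

On these data alone, the reading for 2-methylphenyl at this position remains open. So does whether 3-hydroxyphenyl, 4-hydroxyphenyl or a ring bearing a carboxylic acid would sit with compound 1 or with compound 3.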